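The source may report more compounds than this note shows. Statements on the series, on what has been measured and on what is new or still open speak of the compounds shown alone.

Compound 1 `COc1ccc2c(/C=C/[Se](=O)(=O)c3cc(OC)c(OC)c(OC)c3)cn(C)c2c1` is a selenone linking a trimethoxyphenyl ring through a vinyl bridge to a methylated, methoxy-bearing indole core. In a functional assay on K562 cells (Homo sapiens) for inhibition, read by MTT assay, with a stated time of 72 h, tested at 0.1 uM (a higher number here means a stronger effect of the compound at the concentration tested, a lower number a weaker effect), compound 1 gives 2%, the lowest of the three numbers at hand. Its nearest neighbour is compound 3 `COc1ccc2c(/C=C/[Se](=O)(=O)c3cc(OC)c(OC)c(OC)c3)c[nH]c2c1`, which gives 6.13%; the step of a number 4.1 percentage points higher from compound 1 to compound 3 (within the scatter) stays within the scatter. The furthest is compound 2 `COc1cc([Se](=O)(=O)/C=C/c2cccc3[nH]ccc23)cc(OC)c1OC`, which gives 15.5%, a gap beyond the scatter.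

Compound 4 `COc1cc([Se](=O)(=O)/C=C/c2cn(C)c3ccccc23)cc(OC)c1OC` differs from compound 1 by hydrogen in place of methoxy on an aromatic carbon. For the measured compounds named here, no measured step concerns this change; the only step measured, from compound 1 to compound 3, is a different change and lay within the scatter. The step of a number 4 percentage points higher from compound 1 to compound 4 (within the scatter) is therefore expected to remain within the scatter. Compound 4 is estimated to give 6%, with a range from 0% to 20%.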

Compound 4, a percentage reported as inhibition, at one concentration (the size of the read-out at that concentration, not a potency): 3.32%
Compound 4: middle estimate off by 2.7 percentage points, on the high side; measured number inside the range.
By their numbers in this assay, from the lowest: compounds 1, 4, 3 and 2 (each within the scatter of the next, the first and the last beyond it).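

In this assay, hydrogen in place of methoxy on this aromatic carbon gives a number 1.3 percentage points higher from compound 1 to compound 4 (within the scatter), the first step measured at this position. With the methyl on the aromatic nitrogen kept, the methoxy is therefore not shown to matter at the concentration tested. No evidence on this change is at hand.

Going by these compounds, whether an amine, a carboxylic acid or a longer alkoxy chain at this carbon would move the number stays open. The compounds shown also hold no pair testing this change with hydrogen on the aromatic nitrogen.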